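Sulfonyl aryl swap on the shared core: compound 3 to compound 4

A few compounds are considered here, and "the series" means these few. Any claim that something is new, unique, unknown or untested is made for them only; others in the source may bear on it.

Measured so far in an ADME assay on microsomes from liver (Homo sapiens) for metabolic stability, tested at 2.5 uM; on this read-out higher numbers stand for fast clearance and lower numbers for slow clearance:
- compound 1, `O=S(=O)(c1ccc(F)c(Cl)c1)c1cnc2c(F)cccc2c1-c1ccc(F)cc1`, gives 0.19 mL/min
- compound 2, `N#Cc1cccc(S(=O)(=O)c2cnc3c(F)cccc3c2-c2cccc(Cl)c2)c1`, gives 1.11 mL/min
- compound 3, `O=S(=O)(c1cc(Cl)cc(Cl)c1)c1cnc2c(F)cccc2c1-c1ccc(F)cc1`, gives 1.01 mL/min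

Compound 3 stands second highest of the three numbers in this assay. Compound 2 is its nearest neighbour, within the scatter of it; compound 1 is furthest, and the step of a 5.3-fold higher number from compound 1 to compound 3 (0.73 log units; beyond the scatter) is beyond the scatter.

Compound 4, `N#Cc1cccc(S(=O)(=O)c2cnc3c(F)cccc3c2-c2ccc(F)cc2)c1`, is not yet measured. It differs from compound 3 in one place: 3-cyanophenyl in place of 3,5-dichlorophenyl on a sulfonyl sulfur.

For the measured compounds named here, only one measured step touches the aryl group on the sulfonyl sulfur, a 5.3-fold higher number from compound 1 to compound 3 (0.73 log units; beyond the scatter), and it goes from 3-chloro-4-fluorophenyl to 3,5-dichlorophenyl, not to 3-cyanophenyl, so it bears only indirectly on this change. Compound 2 carries the same 3-cyanophenyl on its sulfonyl sulfur, with a different group elsewhere on the core, and in this assay compound 2 gives 1.11 mL/min, close to compound 3. The step is therefore expected to be a 1.1-fold lower number from compound 3 to compound 4 (0.05 log units; within the scatter), within the scatter. Compound 4 is estimated at 0.9 mL/min, in the range 0.4 mL/min to 2 mL/min.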

Compound 4, intrinsic clearance in a liver preparation (reported as CLH), per the amount of preparation that the assay uses: 0.19 mL/min
Compound 4: the middle estimate sits 4.7-fold (0.68 log units) above what was measured; the measured number lies below the stated range.
By their numbers in this assay, from the lowest: compounds 1 and 4 (each within the scatter of the next); then compounds 3 and 2 (each within the scatter of the next).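

In this assay, the step of a 5.3-fold lower number from compound 3 to compound 4 (0.73 log units; beyond the scatter) shows that 3-cyanophenyl on the sulfonyl sulfur goes with a clearly lower number than 3,5-dichlorophenyl, a second step at this position beyond the scatter. With no change at the digits printed from compound 1 to compound 4 (within the scatter), 3-cyanophenyl and 3-chloro-4-fluorophenyl cannot be told apart here, so among these three aryl groups on the 4-fluorophenyl-bearing core, only 3,5-dichlorophenyl stands apart. The step of a 5.8-fold lower number from compound 2 to compound 4 (0.77 log units; beyond the scatter), with 4-fluorophenyl in place of 3-chlorophenyl on an aromatic carbon and 3-cyanophenyl held fixed, shows that the number also moves beyond the scatter with a change away from the sulfonyl sulfur.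

Nothing on hand gives a reason for any of these steps. From the compounds shown here alone, whether an amine or a carboxylic acid on the sulfonyl aryl group would fall with the low or the high numbers remains open, as does whether the 4-fluorophenyl step holds with other aryl groups on the sulfonyl sulfur.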